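The compounds below may be only part of what the source reports. "The series", "measured", "known", "first", "only" and "open" are said of these compounds alone.

Measured so far in an assay on HEK293 cells with D(4) dopamine receptor (Homo sapiens) as the target, read by FLIPR; on this read-out lower numbers stand for smaller maximal responses and higher numbers for larger maximal responses:
- compound 1 `Fc1cccnc1N1CCN(Cc2nc3ccccc3[nH]2)CC1` gives 27%
- compound 2 `N#Cc1cccnc1N1CCN(Cc2nc3ccccc3[nH]2)CC1` gives 50%
- compound 3 `O=[N+]([O-])c1ccccc1N1CCN(Cc2nc3ccccc3[nH]2)CC1` gives 40%

Compound 3 has the second highest of the three numbers in this assay. Its value and that of compound 2 lie within the usual scatter of each other, so no order between them can be read; compound 1 sits clearly lower than compound 3.

Compound 4 `Fc1ccccc1N1CCN(Cc2nc3ccccc3[nH]2)CC1` has not yet been measured. It differs from compound 3 in one place: fluoro in place of nitro on an aromatic carbon.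

For the measured compounds named here, no measured pair swaps nitro for fluoro, so the step from compound 3 to compound 4 has no direct counterpart. Going by the values given here, the only step that touches fluoro is the change from compound 1 to compound 2, a number 23 percentage points higher from compound 1 to compound 2 (beyond the scatter), where a fluoro compound gave the lower number. Compound 1 is also the lowest of the three, which points the same way. A drop beyond the scatter therefore seems likely, though its size is uncertain.

Compound 4 is expected to give about 28% in this assay, most likely between 15% and 42%, an estimated step of a number 12 percentage points lower from compound 3 to compound 4 (beyond the scatter).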

Compound 4, largest response reached (reported as efficacy), in percent of the reference or control that the assay uses: 42%
Compound 4: the middle estimate sits 14 percentage points below what was measured; the range from low to high includes it.
By their numbers in this assay, from the lowest: compound 1; then compounds 3, 4 and 2 (each within the scatter of the next).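

In this assay the reading is a number 2 percentage points higher from compound 3 to compound 4 (within the scatter) as fluoro replaces nitro on an aromatic carbon ortho to a large group, so this position shows no readable difference between a group of three heavy atoms and a group of one. With 2-fluorophenyl in place of 3-cyanopyridin-2-yl there is a number 8 percentage points lower from compound 2 to compound 4 (within the scatter) and no order can be read, whereas with 2-fluorophenyl in place of 3-fluoropyridin-2-yl there is a number 15 percentage points higher from compound 1 to compound 4 (beyond the scatter) and the gap is real, though modest. Fluoro alone therefore does not go with the low number, since compound 1 and compound 4 both carry it and still differ beyond the scatter.

Nothing available here explains these numbers. As far as these compounds go, whether an amine, a methoxy group or a longer chain on this same aromatic carbon would give a number like those of compound 3 and compound 4 stays open.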